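Formyl-heteroaryl exchange on the shared core: compound 1 to compound 3

A few compounds are considered here, and "the series" means these few. Any claim that something is new, unique, unknown or untested is made for them only; others in the source may bear on it.

Measured so far:
compound 1 `O=Cc1ccc(-c2cncc(Cl)c2N2CCC3(CCNC3=O)CC2)o1` — 5190 nM
compound 2 `CC(C)(C)OC(=O)N1CCN(Cc2ccc(-c3cncc(Cl)c3N3CCC4(CCNC4=O)CC3)s2)CC1` — 5150 nM

Among the compounds with values here, in a functional assay on MV4-11 cells (Homo sapiens) for inhibition, read by resazurin assay, with a stated time of 72 h (on this read-out lower numbers stand for stronger inhibition of growth and higher numbers for weaker inhibition of growth), compound 1 gives 5190 nM, the highest of the two numbers so far. Compound 2 gives 5150 nM in this assay, a value within the scatter of compound 1, so no order between the two is claimed. Compound 3 `O=Cc1sccc1-c1cncc(Cl)c1N1CCC2(CCNC2=O)CC1` is not yet measured in this assay. It differs from compound 1 in one place: 2-formylthiophen-3-yl in place of 5-formylfuran-2-yl on an aromatic carbon. Within the data shown here, no step between two measured compounds is available to size such an exchange, and the two measured values give no hint of a direction. The step of a 1.0-fold lower number from compound 1 to compound 3 (0.02 log units; within the scatter) is therefore expected to be none beyond the scatter. Among the measured compounds shown here, compound 3 is estimated at 5000 nM in this assay, with a range from 1800 nM to 14000 nM; the range is wide, as the data hold no precedent for this exchange.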

Compound 3, concentration for 50% growth inhibition: 28700 nM
Beside the measured number, compound 3's estimate is 5.7-fold (0.76 log units) below it; measured number above the stated range.
By their numbers in this assay, from the lowest: compounds 2 and 1 (each within the scatter of the next); then compound 3.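

In this assay, within the data shown here, the aromatic carbon ortho to a large group proves sensitive to the heteroaryl it carries: 2-formylthiophen-3-yl in place of 5-formylfuran-2-yl gives a 5.5-fold higher number from compound 1 to compound 3 (0.74 log units; beyond the scatter) and so weaker inhibition of growth, the first step that lies beyond the scatter. The two groups match in heavy-atom count, ring size, double bonds outside the ring and hydrogen-bond counts, yet differ in the ring hetero atom, sulfur for oxygen, and in where the formyl group stands on the ring. No measurement available here accounts for the step. The compounds shown do not separate the effect of the sulfur from that of the formyl placement. Also open, as far as these compounds go, is how a carboxylic acid or a nitrile in place of the formyl group would read.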